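The compounds below may be only part of what the source reports. "The series", "measured", "known", "first", "only" and "open" are said of these compounds alone.

Measured so far:
compound 1 `CCOC(=O)c1c(CSc2ccc(OC)cc2)n(C)c2ccc(O)cc12`: 2300 nM
compound 2 `CCOC(=O)c1c(CSc2ccc(OC(F)(F)F)cc2)n(C)c2ccc(O)cc12`: 900 nM

Among the measured compounds shown here, in an assay for inhibition of Polyunsaturated fatty acid 5-lipoxygenase (Homo sapiens), read by HPLC, with a stated time of 10 min (a higher number here means a weaker inhibitor, a lower number a stronger inhibitor), compound 1 gives 2300 nM, the higher of the two numbers; compound 2 gives 900 nM, and the step of a 2.6-fold lower number from compound 1 to compound 2 (0.41 log units; beyond the scatter) is the only change measured so far. Compound 3 `CCOC(=O)c1c(CSc2c(C)cccc2C)n(C)c2ccc(O)cc12` exchanges the ring that hangs from the sulfur: 2,6-dimethylphenyl in place of 4-methoxyphenyl on a sulfur. For the measured compounds named here, no measured step swaps this whole ring; the step from compound 1 to compound 2 shows only that altering it can shift the number modestly. The expectation is therefore a step not beyond the scatter, a 1.2-fold lower number from compound 1 to compound 3 (0.06 log units; within the scatter). Compound 3 is estimated at 2000 nM, with a range from 600 nM to 6000 nM.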

Compound 3, half-maximal inhibitory concentration: 800 nM
Estimate against measurement, compound 3: 2.5-fold (0.40 log units) above; the range from low to high includes it.
By their numbers in this assay, from the lowest: compounds 3 and 2 (each within the scatter of the next); then compound 1.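

Replacing the whole ring on the sulfur gives a 2.9-fold lower number from compound 1 to compound 3 (0.46 log units; beyond the scatter) in this assay and so goes further than compound 2, which changed only the group on the ring's oxygen. Compound 3 carries 2,6-dimethylphenyl, which has no oxygen, so a number lower than that of compound 1 does not require the oxygen of 4-methoxyphenyl. Nothing shown here gives a cause for this step.

Still open, on these data alone, is how a pyridine ring on the sulfur would read, or a phenyl ring carrying a single methyl group. As far as these compounds go, the effect of a carboxylic acid in place of the ethyl ester also remains unknown.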